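From vinyl to indazole on the shared core

This account rests on a few compounds, and the source may have more. Where it says the series, first, only, none or still open, it means among the compounds named here.

Measured so far in a functional assay on HeLa cells (Homo sapiens) for inhibition, read by CCK-8 assay, with a stated time of 48 h; a higher number here means a weaker inhibitor, a lower number a stronger inhibitor:
Compound 1 `COc1cc(-c2ccnc3cc(-c4ccc(C)cc4)nn23)cc(OC)c1OC` gives 21 nM
Compound 2 `C=Cc1ccc(-c2cc3nccc(-c4cc(OC)c(OC)c(OC)c4)n3n2)cc1` gives 882 nM

Among the measured compounds shown here, compound 2 holds the higher of the two numbers, and compound 1 is its only neighbour. Compound 3 `COc1cc(-c2ccnc3cc(-c4ccc5cnn(C)c5c4)nn23)cc(OC)c1OC` keeps the shared core and carries 1-methyl-1H-indazol-6-yl in place of 4-vinylphenyl on an aromatic carbon. For the measured compounds named here, the only measured step that bears on this place is large and beyond the scatter (a 42-fold higher number from compound 1 to compound 2 (1.62 log units; beyond the scatter)), so a small edit to this group has already moved the number far. Going by the values given here, no measured compound carries 1-methyl-1H-indazol-6-yl, which leaves the size uncertain. A large step to a lower number is nevertheless expected in this assay, back toward compound 1 (21 nM). The expected step is a 22-fold lower number from compound 2 to compound 3 (1.34 log units; beyond the scatter) in size. Compound 3 is estimated at 40 nM (expected range 10 nM to 200 nM).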

Compound 3, half-maximal inhibitory concentration: 97 nM
For compound 3 the middle estimate is 2.4-fold (0.38 log units) below the measured one, and the stated range covers the measured number.
By their numbers in this assay, from the lowest: compound 1; then compound 3; then compound 2.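

In this assay, the place on the five-membered aromatic ring also accepts a group of two fused aromatic rings with 2 hydrogen-bond acceptors: 1-methyl-1H-indazol-6-yl in place of 4-vinylphenyl gives a 9.1-fold lower number from compound 2 to compound 3 (0.96 log units; beyond the scatter) and recovers much of the distance separating compound 2 from compound 1. The recovery is only partial, since 1-methyl-1H-indazol-6-yl in place of 4-methylphenyl gives a 4.6-fold higher number from compound 1 to compound 3 (0.66 log units; beyond the scatter) and leaves the small methyl-bearing phenyl ring as the best of the three groups shown at this place. No evidence is available on what lies behind these two steps.

The compounds shown leave open whether the ring nitrogens or the added fused ring account for the difference from 4-vinylphenyl. They also leave open how an amine, a carboxylic acid or an ethyl group on the phenyl ring would compare with the methyl of compound 1.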